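Pyrazine ether from chloro to hydrogen: an expected gain

The source may report more compounds than this note shows. Statements on the series, on what has been measured and on what is new or still open speak of the compounds shown alone.

Measured compounds:
compound 1 `Brc1cncc(OC[C@@H]2C[C@@H]3C[C@@H]3N2)c1` gives 2.9 nM in an assay on CHO-K1 cells for displacement of a labelled ligand from Neuronal acetylcholine receptor; alpha4/beta2 (Homo sapiens), read by scintillation counting; on this read-out lower numbers stand for stronger inhibition and higher numbers for weaker inhibition
compound 2 `Clc1nccnc1OC[C@@H]1C[C@H]2C[C@H]2N1` gives 5110 nM in this assay
compound 3 `Cc1ccc(OC[C@@H]2C[C@H]3C[C@H]3N2)cn1` gives 26.2 nM in this assay

Among the three, compound 2 has the highest number by a wide margin: compound 3 comes nearest, and compound 1 is furthest away, both gaps well beyond the usual scatter. The three share a core of a bicyclic amine joined through an ether to an aromatic ring, and they differ only in that ring and what sits on it.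

Compound 4 `c1cnc(OC[C@@H]2C[C@H]3C[C@H]3N2)cn1` is not yet measured. The change from compound 2 to compound 4 is hydrogen in place of chloro on an aromatic carbon. For the measured compounds named here, no step between two measured compounds matches this change, so the size of the step has to be judged from the spread seen so far: a ring without a halogen in compound 3 still gives a number far lower than compound 2.

Compound 4 is therefore expected to give 400 nM in this assay, with a range from 40 nM to 4000 nM. The step expected is a 13-fold lower number from compound 2 to compound 4 (1.11 log units; beyond the scatter), a lowering of the number beyond the scatter, though its size is uncertain.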

Compound 4, inhibition constant: > 10000 nM
Compound 4: no number, only a limit; the forecaster's own chance of this, stated with the estimate: 5%; at least 25-fold (1.39 log units) between middle value and limit.
By their numbers in this assay, from the lowest: compound 1; then compound 3; then compound 2. At a limit, above all of these: compound 4.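

In this assay, compound 4 gives > 10000 nM, which is a limit of the assay and not a number. Replacing chloro with hydrogen on this aromatic carbon, next to the ring nitrogen, gives an at least 1.9-fold higher number from compound 2 to compound 4 (0.29 log units; that floor lies within the scatter), so the pair shows no lowering of the number, and the real size of the step cannot be read. Compound 2, for all its high number, therefore cannot be taken to be held back by its chloro, and this reading rests on a single limit: the limit of > 10000 nM in this assay, at which 1 of the 4 values shown sits.

From the compounds shown here alone, whether a different group at this place, such as an amine or a methoxy group, would bring the number down remains open. Also open, going by these compounds, is whether hydrogen in place of chloro would act the same way on another aromatic ring.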